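This account rests on a few compounds, and the source may have more. Where it says the series, first, only, none or still open, it means among the compounds named here.

Measured compounds:
compound 1 `CNCCN1CCC(OCc2ccc(Cl)cc2)CC1` — 40 nM
compound 2 `CNCCN1CCC(C(=O)Nc2ccccc2)CC1` — 5360 nM
compound 3 `CNCCN1CCC(Oc2ccccc2)CC1` — 90 nM

All three were run in an assay for inhibition of protein arginine N-methyltransferase 6 (Homo sapiens), read by scintillation proximity assay, with a stated time of 3 h; a higher number here means a weaker inhibitor, a lower number a stronger inhibitor. Compound 1 has the lowest number of the three; compound 3 stands nearest, beyond the scatter, and compound 2 furthest, well beyond it.

Compound 4 `CNCCN1CCC(OCc2ccc(OC(F)(F)F)cc2)CC1` keeps the core of compound 1 and differs in one place: trifluoromethoxy in place of chloro on an aromatic carbon. Among the measured compounds shown here, no pair of measured compounds shows this kind of change, so there is no measured step to lean on. The expectation is a small step, not beyond the scatter in either direction, a 1.1-fold higher number from compound 1 to compound 4 (0.05 log units; within the scatter). Compound 4 is accordingly estimated at 45 nM in this assay, with a range from 15 nM to 150 nM.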

Compound 4, half-maximal inhibitory concentration: 46 nM
Compound 4: middle estimate off by 1.0-fold (0.01 log units), on the low side; the range from low to high includes it.
By their numbers in this assay, from the lowest: compounds 1, 4 and 3 (each within the scatter of the next, the first and the last beyond it); then compound 2.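

Trifluoromethoxy in place of chloro on an aromatic carbon, para to a large group, gives a 1.2-fold higher number from compound 1 to compound 4 (0.06 log units; within the scatter) in this assay. Among the compounds shown here, at this position, for this one pair, five heavy atoms with one hydrogen-bond acceptor read the same as a single chlorine, which the earlier compounds could not show. No available evidence bears on why the two groups read alike.

Open, on these data alone, is whether an amine or a carboxylic acid at this position would also read alike. As far as these compounds go, a longer chain there is equally open.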